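This account rests on a few compounds, and the source may have more. Where it says the series, first, only, none or still open, it means among the compounds named here.

Measured so far in an assay on isolated protein for binding affinity to 5-hydroxytryptamine receptor 1D (Homo sapiens); a higher number here means a weaker inhibitor, a lower number a stronger inhibitor:

Compound 1, `COc1cc2c(cc1N1C[C@@H](C)N(C)[C@@H](C)C1)N(C(=O)c1ccc(-c3cccc(C)n3)c3ccccc13)CC2`, gives 100 nM.
Compound 2, `COc1cc2c(cc1N1C[C@@H](C)N[C@@H](C)C1)N(C(=O)c1ccc(-c3cccc(C)n3)c3ccccc13)CC2`, gives 126 nM.
Compound 3, `COc1cc2c(cc1N1C[C@@H](C)N(C)[C@@H](C)C1)N(C(=O)c1ccc(-c3ccc(-c4noc(C)n4)cc3C)cc1)CC2`, gives 15.9 nM.

Compound 1 and compound 2 share one core and differ in a single place: hydrogen in place of methyl on an amine nitrogen in a ring. The step of a 1.3-fold higher number from compound 1 to compound 2 (0.10 log units; within the scatter) lies within the scatter, so the two values cannot be told apart and no order between compound 1 and compound 2 is claimed.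

Compound 3 carries a different core. How it differs from compound 1 is not broken down here, since the two differ in more than one place. In this assay compound 3 has the lowest number of the three; its steps to compound 1 and to compound 2 are both beyond the scatter, so among the three measured compounds it is the strongest binder.

Compound 4, `COc1cc2c(cc1N1C[C@@H](C)N[C@@H](C)C1)N(C(=O)c1ccc(-c3ccc(-c4noc(C)n4)cc3C)cc1)CC2`, has not yet been measured. It stands to compound 3 as compound 2 stands to compound 1: hydrogen in place of methyl on an amine nitrogen in a ring. The surroundings of the changed place read the same, word for word, in both pairs, so this is the same change made on the core of compound 3.

Going by the values given here, the one measured instance of this change produced a step within the scatter, namely a 1.3-fold higher number from compound 1 to compound 2 (0.10 log units; within the scatter). On that basis the step from compound 3 to compound 4 is expected to be about as small, a 1.3-fold higher number from compound 3 to compound 4 (0.10 log units; within the scatter). Compound 4 is therefore estimated at 20 nM in this assay, with a likely range from 9 nM to 45 nM. This rests on a single measured example of the change, and on the assumption that it behaves alike on the two cores.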

Compound 4, inhibition constant: 251 nM
Compound 4: the middle estimate sits 13-fold (1.10 log units) below what was measured; the whole stated range lies below it.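

In this assay, putting hydrogen in place of methyl on the amine nitrogen of the ring gives a 16-fold higher number from compound 3 to compound 4 (1.20 log units; beyond the scatter), so on this core the methyl group clearly counts for binding. Set beside the earlier pair, the size of this step does not carry over from one core to the other, and a small step on one core gave no safe guide to the step on the other: the same change on two cores in this assay, a 1.3-fold higher number (0.10 log units; within the scatter) from compound 1 to compound 2 and a 16-fold higher number (1.20 log units; beyond the scatter) from compound 3 to compound 4, 13-fold (1.10 log units) apart, beyond the scatter of two such steps. The two cores differ in more than one place, so these two pairs do not show which difference sets the size of the step, why the step changes, or how the same change would behave on a third core.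

The compounds shown leave open whether methyl is the only group that serves on this nitrogen of the core of compound 3, or whether an ethyl group, a longer chain or an acetyl group would give a number closer to that of compound 3 or of compound 4. They also leave open whether the step would stay as large if hydrogen replaced the methyl groups on the two ring atoms that each bear one.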